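The source may hold more compounds than are shown below. What is called first, only, known or untested is meant among the compounds shown, and "the series" means these compounds.

Measured so far:
- compound 1, `O=C(COc1cccc2ccccc12)N/N=C/c1ccccc1Br`: 100 ug/mL in an ADME assay on HEL cells (Homo sapiens) for cytotoxicity; on this read-out higher numbers stand for lower toxicity in this test and lower numbers for higher toxicity in this test
- compound 2, `C/C(=N\NC(=O)COc1cccc2ccccc12)c1ccc(Cl)cc1`: 7.1 ug/mL in this assay

Both compounds share the same core and differ only in the group hanging from the hydrazone carbon. Of the two numbers in this assay, compound 1 has the higher one: compound 2 sits well below it, and that gap is larger than the scatter of repeated measurements, so compound 1 is the less toxic of the pair in this test.

The step from compound 1 to compound 3, `O=C(COc1cccc2ccccc12)N/N=C/c1ccccc1O`, is a single substitution on the ring attached to the hydrazone: hydroxy in place of bromo on an aromatic carbon. Among the compounds with values here, no measured pair in this set shows what this particular exchange does in this assay, so its effect is an open question. With so little to go on, the expected step of a 1.7-fold lower number from compound 1 to compound 3 (0.22 log units; within the scatter) is a modest decrease, within or only slightly beyond the scatter. Compound 3 is therefore estimated to give 60 ug/mL in this assay, with a likely range from 15 ug/mL to 150 ug/mL, and the actual measurement will settle whether the hydroxy group moves the value at all.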

Compound 3, half-maximal cytotoxic concentration: 3.57 ug/mL
The estimate for compound 3 lay 17-fold (1.23 log units) above the measured number; the whole stated range lies above it.
By their numbers in this assay, from the lowest: compounds 3 and 2 (each within the scatter of the next); then compound 1.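

Within the data shown here, this pair differs in one place only, so it gives the first direct look at this position on the ring. In this assay, going from 2-bromophenyl to 2-hydroxyphenyl gives a 28-fold lower number from compound 1 to compound 3 (1.45 log units; beyond the scatter), which means higher toxicity in this test. The site, an aromatic carbon ortho to a large group, is therefore far from silent: exchanging one heavy atom for one other heavy atom, with the rest of the molecule unchanged, is enough to produce a large step, and nothing available here accounts for its size.

Going by these compounds, what remains open is whether this step comes from gaining the hydroxy group or from losing the bromo group, since a single exchange changes both at once. Compounds carrying a methoxy group, an amine or a chlorine at this same site could begin to separate those two readings, and placing the hydroxy group elsewhere on the ring could show whether the step depends on this particular site.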